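A few compounds are considered here, and "the series" means these few. Any claim that something is new, unique, unknown or untested is made for them only; others in the source may bear on it.

Compound 1 `C=CCOn1c(-c2cccc(C#N)c2)nc(C)c1C(=O)OCC`: 5860 nM
Compound 2 `CCOC(=O)c1c(C)nc(-c2cccc(C#N)c2)n1OCCC(=O)O`: > 30000 nM

Within the data shown here, in a functional assay on a cell-free system (plasma, Oryctolagus cuniculus) for inhibition, with stated times of 5 min, 1 min and 6 min (on this read-out lower numbers stand for stronger inhibition and higher numbers for weaker inhibition), compound 1 gives 5860 nM, the only true number so far. Compound 2 reaches > 30000 nM, which is a limit of the assay and not a number. Compound 3 `C=CCOn1c(-c2cccc(C#N)c2)nc(C)c1C(=O)O` has hydrogen in place of ethyl on an oxygen next to a carbonyl group, turning ethoxycarbonyl into carboxy (hydrogen in place of ethyl on an oxygen next to a carbonyl group). One measured step offers a guide, though it changes another place: carboxymethyl enters in an at least 5.1-fold higher number from compound 1 to compound 2 (0.70 log units; beyond the scatter), and inhibition weakens. Compound 2 thus suggests that a similar weakening is expected here, as a 2.6-fold higher number from compound 1 to compound 3 (0.41 log units; beyond the scatter) in this assay. For compound 3 the estimate is 15000 nM, with an expected range from 3000 nM to 60000 nM.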

Compound 3, half-maximal inhibitory concentration: 6350 nM
The estimate for compound 3 lay 2.4-fold (0.37 log units) above the measured number; measured number inside the range.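

Ethoxycarbonyl and carboxy give numbers that stand level in this assay (a 1.1-fold higher number from compound 1 to compound 3 (0.03 log units; within the scatter)). On an oxygen next to a carbonyl group, then, the ethyl is not needed to keep this level of inhibition, and the free carboxy is tolerated. The weakening seen with carboxymethyl at the other place (an at least 5.1-fold higher number from compound 1 to compound 2 (0.70 log units; beyond the scatter)) does not carry over to this place, and compound 2 stands at a limit, not a number: the limit of > 30000 nM in this assay, at which 1 of the 3 values shown sits.

As far as these compounds go, what an amide or a longer chain in place of the ethoxy would do stays open.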